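Replacing 4-methylphenyl with 2-methoxyphenyl on a shared core

The source may hold more compounds than are shown below. What is called first, only, known or untested is meant among the compounds shown, and "the series" means these compounds.

In an ADME assay on MDBK cells (Bos taurus) for cytotoxicity (a higher number here means that more compound is tolerated, a lower number that less compound is tolerated), compound 1 `Fc1cccc(F)c1Cn1ccc2nc(-c3ccccc3)nc-2c1` gives > 100000 nM as its result, and that value is a limit of the assay. Compound 2 `Cc1ccc(Cn2ccc3nc(-c4ccccc4)nc-3c2)cc1` gives > 100000 nM as its result, again a limit and not a number, so it stands without a measured value of its own. For the measured compounds named here, the only measured step is a step that the two limits leave unreadable from compound 1 to compound 2 and it offers no size to carry forward.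

Compound 3 `COc1ccccc1Cn1ccc2nc(-c3ccccc3)nc-2c1` differs from compound 2 by 2-methoxyphenyl in place of 4-methylphenyl on a saturated chain carbon bound to an aromatic nitrogen and so carries 2-methoxyphenyl in place of 4-methylphenyl on a saturated chain carbon bound to an aromatic nitrogen. The measured compounds supply only the limit of > 100000 nM in this assay, at which 2 of the 2 values shown sit, as a guide. On that basis, compound 1 and compound 2 lead to the expectation of no step beyond the scatter in this assay and of no particular direction. The estimated change is a number no higher from compound 2 to compound 3 (the limit leaves the size open) on this reading. For compound 3 the expected value is 100000 nM with an estimated range from 50000 nM to 200000 nM and a further limit is the likeliest report.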

Compound 3, half-maximal cytotoxic concentration: > 100000 nM
Compound 3: a limit, no number; the forecaster's own chance of this, stated with the estimate: 80%; the middle value lies on the limit itself.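

In this assay the result for compound 3, like those for compound 1 and compound 2, is a limit and not a number, so no step among these compounds can be read. All the values shown stand at one point: the limit of > 100000 nM in this assay, at which 3 of the 3 values shown sit.

The compounds shown leave open the concentration at which any of them would reach half-maximal cytotoxicity, and whether exchanging the aromatic group alters it.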